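Seven-membered rings on the sulfonyl sulfur: cytotoxicity notes

The source may hold more compounds than are shown below. What is called first, only, known or untested is meant among the compounds shown, and "the series" means these compounds.

- compound 1 `O=C(Nc1ccc(F)c(Cl)c1)c1ccc(F)c(S(=O)(=O)N2CCOC[C@H](O)C2)c1` gives 19000 nM
- compound 2 `O=C(Nc1ccc(F)c(Cl)c1)c1ccc(F)c(S(=O)(=O)N2CCCCC(CO)C2)c1` gives 3100 nM
- compound 3 `O=C(Nc1ccc(F)c(Cl)c1)c1ccc(F)c(S(=O)(=O)N2CCCC(O)CC2)c1` gives 29000 nM

Compound 3 sits level with compound 1 in an ADME assay on HepG2 2.2.15 cells (Homo sapiens) for cytotoxicity, read by luminescence, with a stated time of 3 days; on this read-out lower numbers stand for higher toxicity in this test and higher numbers for lower toxicity in this test (a 1.5-fold higher number from compound 1 to compound 3 (0.18 log units; within the scatter)) and well clear of compound 2 (a 9.4-fold higher number from compound 2 to compound 3 (0.97 log units; beyond the scatter)). Compound 2 is also separated from the other member of the pair (a 6.1-fold lower number from compound 1 to compound 2 (0.79 log units; beyond the scatter)).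

The change leading to compound 4 `CN1CCN(S(=O)(=O)c2cc(C(=O)Nc3ccc(F)c(Cl)c3)ccc2F)CC(O)C1` lies on a sulfonyl sulfur (6-hydroxy-4-methyl-1,4-diazepan-1-yl in place of 4-hydroxyazepan-1-yl on a sulfonyl sulfur). The closest measured precedent is the swap of 6-hydroxy-1,4-oxazepan-4-yl for 4-hydroxyazepan-1-yl (a 1.5-fold higher number from compound 1 to compound 3 (0.18 log units; within the scatter)), which also exchanges one hydroxy-bearing seven-membered ring for another and stays within the scatter. For the measured compounds named here, both steps beyond the scatter are modest and involve compound 2, the only measured compound with 3-(hydroxymethyl)azepan-1-yl, a group absent from compound 4. Going by the values given here, no measured compound carries 6-hydroxy-4-methyl-1,4-diazepan-1-yl, so the precedent is indirect and the range is kept wide.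

No step beyond the scatter is expected in this assay (estimated as a 1.2-fold lower number from compound 3 to compound 4 (0.08 log units; within the scatter)). The estimate for compound 4 is 24000 nM (expected range 10000 nM to 55000 nM).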

Compound 4, half-maximal cytotoxic concentration: 31000 nM
Estimate against measurement, compound 4: 1.3-fold (0.11 log units) below; measured number inside the range.
By their numbers in this assay, from the lowest: compound 2; then compounds 1, 3 and 4 (each within the scatter of the next).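

In this assay, 6-hydroxy-4-methyl-1,4-diazepan-1-yl on a sulfonyl sulfur reads the same as 4-hydroxyazepan-1-yl (a 1.1-fold higher number from compound 3 to compound 4 (0.03 log units; within the scatter)), so a methyl-bearing ring nitrogen joins the ring oxygen of 6-hydroxy-1,4-oxazepan-4-yl as a change with no readable effect on this read-out. The two hetero-atom rings also match each other (a 1.6-fold higher number from compound 1 to compound 4 (0.21 log units; within the scatter)), which leaves three hydroxy-bearing seven-membered rings within the scatter of one another. For the compounds shown here, the separation of the 3-(hydroxymethyl)azepan-1-yl group now holds against all three of these rings, including the new one (a 10-fold higher number from compound 2 to compound 4 (1.00 log units; beyond the scatter)), and among the four compounds it is the only group with a step beyond the scatter.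

Nothing available explains why these numbers fall as they do. Still open, going by these compounds, is whether the separation of compound 2 follows from the hydroxymethyl chain itself or from where it sits on the ring, and how an unsubstituted azepan-1-yl, or a ring carrying a primary amine or a carboxylic acid in place of the hydroxy, would read in this assay.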